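Working notes on substituent swaps at one aromatic carbon

This account rests on a few compounds, and the source may have more. Where it says the series, first, only, none or still open, it means among the compounds named here.

Measured so far:
compound 1 `C#Cc1ccnc(O[C@@H]2CC[C@@H](C)N(C(=O)c3ccccc3-n3nccn3)C2)c1`: 240 nM
compound 2 `COC(=O)c1ccnc(O[C@@H]2CC[C@@H](C)N(C(=O)c3ccccc3-n3nccn3)C2)c1`: 1800 nM

In a functional assay on CHO-K1 cells for antagonist activity at Orexin/Hypocretin receptor type 1 (Homo sapiens), read by FLIPR and calcium flux (on this read-out higher numbers stand for weaker inhibition and lower numbers for stronger inhibition), compound 1 gives 240 nM and compound 2 gives 1800 nM. Among the measured compounds shown here, compound 2 therefore stands highest of the two numbers, and the only step that reaches it is a 7.5-fold higher number from compound 1 to compound 2 (0.88 log units; beyond the scatter).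

Compound 3 `C[C@@H]1CC[C@@H](Oc2cc(-c3ccccc3)ccn2)CN1C(=O)c1ccccc1-n1nccn1` differs from compound 2 by phenyl in place of methoxycarbonyl on an aromatic carbon. For the measured compounds named here, no measured step places phenyl at this carbon, so the only step that bears on the change is a 7.5-fold higher number from compound 1 to compound 2 (0.88 log units; beyond the scatter), which shows that an exchange of the group at this position moves the number by a modest amount and that the methoxycarbonyl compound 2 holds the weaker number. Taking methoxycarbonyl away is therefore expected to bring the number back down, with a step estimated at a 5.1-fold lower number from compound 2 to compound 3 (0.71 log units; beyond the scatter). Compound 3 is expected to give about 350 nM, with a range from 70 nM to 1800 nM.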

Compound 3, half-maximal inhibitory concentration: 2400 nM
For compound 3 the middle estimate is 6.9-fold (0.84 log units) below the measured one; measured number outside the range, above it.
By their numbers in this assay, from the lowest: compound 1; then compounds 2 and 3 (each within the scatter of the next).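

In this assay, phenyl in place of methoxycarbonyl gives a 1.3-fold higher number from compound 2 to compound 3 (0.12 log units; within the scatter), so this exchange produces no readable change, although the two groups differ in heavy atoms, ring content and hydrogen-bond acceptors. Phenyl in place of ethynyl gives a 10-fold higher number from compound 1 to compound 3 (1.00 log units; beyond the scatter), so at this carbon, opposite the ring nitrogen, both replacements stand apart from ethynyl by more than the scatter, while remaining within the scatter of each other. Nothing available on these compounds accounts for ethynyl standing apart from the other two groups.

The compounds shown leave open how an amine, a carboxylic acid or a simple methyl group would read at this carbon. They also leave open whether any group here can give a lower number than ethynyl on the same core.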